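Propanoylamino series: removing the cyclopropyl from compound 3

A few compounds are considered here, and "the series" means these few. Any claim that something is new, unique, unknown or untested is made for them only; others in the source may bear on it.

Compound 3 `CCC(=O)NC[C@@H]1C[C@H]1c1cccc2c1C[C@@H](CCCCc1ccccc1)O2` gives 2 nM in an assay on NIH3T3 cells for binding affinity to melatonin receptor type 1B (Homo sapiens) (on this read-out higher numbers stand for weaker inhibition and lower numbers for stronger inhibition), the lowest of the three numbers: compound 2 `O=C(NC[C@@H]1C[C@H]1c1cccc2c1C[C@@H](CCCCc1ccccc1)O2)C1CC1` gives 5 nM and compound 1 `CC(C)C(=O)NCCCc1cccc2c1C[C@@H](CCCCc1ccccc1)O2` gives 40 nM. Compound 4 `CCC(=O)NCCCc1cccc2c1C[C@@H](CCCCc1ccccc1)O2` is unmeasured and differs from compound 3 by 3-(propanoylamino)propyl in place of 2-((propanoylamino)methyl)cyclopropyl on an aromatic carbon. Within the data shown here, two steps bear on it. a 20-fold lower number from compound 1 to compound 3 (1.30 log units; beyond the scatter) combines a change at the carbonyl carbon with loss of the three-membered non-aromatic ring. a 2.5-fold lower number from compound 2 to compound 3 (0.40 log units; beyond the scatter) shows a carbonyl change alone, though not the same one. The two steps do not separate the change at the carbonyl carbon from the change of the ring, and the first of them is the large one. A higher number in this assay is therefore expected, a 7.5-fold higher number from compound 3 to compound 4 (0.88 log units; beyond the scatter). The estimate for compound 4 is 15 nM, with a range from 5 nM to 45 nM.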

Compound 4, inhibition constant: 20 nM
For compound 4 the middle estimate is 1.3-fold (0.12 log units) below the measured one; measured number inside the range.
By their numbers in this assay, from the lowest: compound 3; then compound 2; then compounds 4 and 1 (each within the scatter of the next).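

With the propanoyl amide held fixed, the open 3-(propanoylamino)propyl chain on this aromatic carbon is now read alone: a 10-fold higher number from compound 3 to compound 4 (1.00 log units; beyond the scatter). On the open chain, the extra methyl of the isopropylcarbonyl amide leaves no readable difference, with a 2.0-fold lower number from compound 1 to compound 4 (0.30 log units; within the scatter), so the earlier large step from the ring-bearing compound is carried by the ring change. No measurement shown gives a reason for this. Still open, as far as these compounds go, are whether the cyclopropylcarbonyl amide loses as much on the open chain, and whether an acetyl group or a longer acyl chain behaves alike on both linkers.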